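A few compounds are considered here, and "the series" means these few. Any claim that something is new, unique, unknown or untested is made for them only; others in the source may bear on it.

Measured so far in a functional assay on HeLa cells (Homo sapiens) for antiproliferative activity, read by MTT assay, with a stated time of 48 h; on this read-out higher numbers stand for weaker inhibition and lower numbers for stronger inhibition:
compound 1 `COc1cc(-c2nnc(SCC(=O)c3ccccc3)n2N)cc(OC)c1OC`
compound 2 `COc1cc(-c2nnc(SCC(=O)c3ccc(Br)cc3)n2N)cc(OC)c1OC`
compound 3 `COc1cc(-c2nnc(SCC(=O)c3ccc(C)cc3)n2N)cc(OC)c1OC`

This assay reports only a limit for compound 1, > 100000 nM. Compound 2 gives 10400 nM, and compound 3 gives 2940 nM. Compound 3 holds the lowest of the two numbers; its nearest neighbour is compound 2, with a 3.5-fold lower number from compound 2 to compound 3 (0.55 log units; beyond the scatter). Compound 4 `COc1cc(-c2nnc(SCC(=O)c3ccc(C(F)(F)F)cc3)n2N)cc(OC)c1OC` differs from compound 3 by trifluoromethyl in place of methyl on an aromatic carbon. Going by the values given here, no measured step exchanges methyl for trifluoromethyl. Among the compounds with values here, the steps that bear on it are an at least 34-fold lower number from compound 1 to compound 3 (1.53 log units; beyond the scatter), an at least 9.6-fold lower number from compound 1 to compound 2 (0.98 log units; beyond the scatter) and a 3.5-fold lower number from compound 2 to compound 3 (0.55 log units; beyond the scatter): the group on this aromatic carbon sets the number, and bromo gave a higher number than methyl. A modest rise from compound 3 is therefore expected. Compound 4 is estimated at 6000 nM, within 2000 nM to 20000 nM. For compound 4 the estimated step is a 2.0-fold higher number from compound 3 to compound 4 (0.31 log units; beyond the scatter).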

Compound 4, half-maximal inhibitory concentration: 3380 nM
For compound 4 the middle estimate is 1.8-fold (0.25 log units) above the measured one; the range from low to high includes it.
By their numbers in this assay, from the lowest: compounds 3 and 4 (each within the scatter of the next); then compound 2. At a limit, above all of these: compound 1.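

In this assay, trifluoromethyl and methyl at this place, para to a large group, cannot be told apart: a 1.1-fold higher number from compound 3 to compound 4 (0.06 log units; within the scatter). Bromo stays apart from trifluoromethyl, with a 3.1-fold lower number from compound 2 to compound 4 (0.49 log units; beyond the scatter), so swapping the group here does not always change the number, and does not always leave it unchanged. Trifluoromethyl in place of hydrogen reads as an at least 29-fold lower number from compound 1 to compound 4 (1.47 log units; beyond the scatter), a bound set by a limit: the limit of > 100000 nM in this assay, at which 1 of the 4 values shown sits.

Open, from the compounds shown here alone, is where an amine or a carboxylic acid on this aromatic carbon would fall relative to these values. Also open, going by these compounds, is whether the match between methyl and trifluoromethyl holds on a changed core.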